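Sulfonamide aryl change: bromophenyl to dimethylphenyl

This account rests on a few compounds, and the source may have more. Where it says the series, first, only, none or still open, it means among the compounds named here.

For the measured compounds named here, compound 3 `O=C1NCCN1c1ccc(S(=O)(=O)Nc2ccc(Br)cc2)cc1` sits second highest of the three numbers so far in a functional assay on MCF7 cells (Homo sapiens) for antiproliferative activity, read by sulforhodamine B assay, with a stated time of 48 h (a lower number here means a stronger inhibitor, a higher number a weaker inhibitor), where compound 3 gives 240 nM. Its nearest neighbour is compound 1 `O=C1NCCN1c1ccc(S(=O)(=O)Nc2cccc(Br)c2)cc1`, which in this assay gives 100 nM; the furthest is compound 2 `O=C1NCCN1c1ccc(S(=O)(=O)Nc2ccc(I)cc2)cc1`, which in this assay gives 600 nM. All three measured steps concern the aryl group on the sulfonamide nitrogen: a 2.4-fold higher number from compound 1 to compound 3 (0.38 log units; beyond the scatter), a 2.5-fold lower number from compound 2 to compound 3 (0.40 log units; beyond the scatter) and a 6.0-fold higher number from compound 1 to compound 2 (0.78 log units; beyond the scatter).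

Compound 4 `Cc1cccc(NS(=O)(=O)c2ccc(N3CCNC3=O)cc2)c1C` differs from compound 3 in one place: 2,3-dimethylphenyl in place of 4-bromophenyl on a sulfonamide nitrogen. The 4-bromophenyl leaves and a 2,3-dimethylphenyl enters, on the sulfonamide nitrogen whose other neighbour is the sulfonyl sulfur. The steps from compound 1 to compound 3 and from compound 2 to compound 3 bear on this only loosely: each exchanges one substituted aryl on that nitrogen for another and moves the number modestly, beyond the scatter but not far. Going by the values given here, no measured compound carries a methyl on that ring, so the direction of the present change is not fixed by the data. A modest step in this assay, leaning toward a higher number, is expected: a 1.5-fold higher number from compound 3 to compound 4 (0.16 log units; within the scatter). Compound 4 is estimated at 350 nM, with a range from 120 nM to 1000 nM.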

Compound 4, half-maximal inhibitory concentration: 230 nM
Estimate against measurement, compound 4: 1.5-fold (0.18 log units) above; the measured number falls inside the stated range.
By their numbers in this assay, from the lowest: compound 1; then compounds 4 and 3 (each within the scatter of the next); then compound 2.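

In this assay, for the compounds shown here, the 2,3-dimethylphenyl group is the first aryl on the sulfonamide nitrogen in this set to carry no halogen, and it reads level with 4-bromophenyl: a 1.0-fold lower number from compound 3 to compound 4 (0.02 log units; within the scatter). A halogen on this ring is therefore not required for a number in this range, since compound 4 also stands clear of the 4-iodophenyl of compound 2, with a 2.6-fold lower number from compound 2 to compound 4 (0.42 log units; beyond the scatter), while the 3-bromophenyl of compound 1 keeps the lowest number of the four, with a 2.3-fold higher number from compound 1 to compound 4 (0.36 log units; beyond the scatter). Nothing measured here explains why the 4-bromophenyl and 2,3-dimethylphenyl compounds read alike.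

The aryl groups shown carry only bromo, iodo or methyl groups, so it remains open how a methoxy, an amine or a carboxylic acid on that ring would read in this assay. Also open, as far as these compounds go, is how a phenyl bearing a single methyl would compare with the 2,3-dimethylphenyl of compound 4, which leaves the part played by each methyl unresolved.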